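Swapping the aryl group on a hydrazone-linked urea series

A few compounds are considered here, and "the series" means these few. Any claim that something is new, unique, unknown or untested is made for them only; others in the source may bear on it.

The three measured compounds share one core and differ only in the aryl group attached to the carbon with a double bond to nitrogen. Compound 1 `CN(C)CCn1cnnc1-c1cc(Oc2ccc(NC(=O)N/N=C/c3ccc(Cl)cc3Cl)cc2F)ccn1` carries a 2,4-dichlorophenyl there, and in an ADME assay on WI-38 cells (Homo sapiens) for cytotoxicity, read by MTT assay, with a stated time of 72 h (on this read-out lower numbers stand for stronger inhibition and higher numbers for weaker inhibition), compound 1 gives 4760 nM. Compound 2 `COc1ccc(OC)c(/C=N/NC(=O)Nc2ccc(Oc3ccnc(-c4nncn4CCN(C)C)c3)c(F)c2)c1` carries a 2,5-dimethoxyphenyl, and in this assay compound 2 is recorded as "not determined" (no result reported). Compound 3 `COc1cc(/C=N/NC(=O)Nc2ccc(Oc3ccnc(-c4nncn4CCN(C)C)c3)c(F)c2)cc(OC)c1OC` carries a 3,4,5-trimethoxyphenyl, and in this assay compound 3 is recorded as "not determined" (no result reported), so no number describes where compound 3 stands; it shares this absence with compound 2.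

Compound 4 `CN(C)CCn1cnnc1-c1cc(Oc2ccc(NC(=O)N/N=C/c3ccc(Cl)cc3)cc2F)ccn1` is reached from compound 3 by 4-chlorophenyl in place of 3,4,5-trimethoxyphenyl on a carbon with a double bond to nitrogen. Among the compounds with values here, no measured pair shows a step of this kind, so its size cannot be read from the data. Compound 4 is the closest relative of compound 1 among the four, differing only in the loss of one chlorine from the aryl group, and the expectation is therefore a number of similar magnitude, with no direction beyond the scatter claimed.

Compound 4 is estimated to give 5000 nM in this assay, in a range from 1500 nM to 20000 nM, because compound 1 gives 4760 nM.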

Compound 4, half-maximal inhibitory concentration: 1870 nM
Beside the measured number, compound 4's estimate is 2.7-fold (0.43 log units) above it, and the stated range covers the measured number.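

Taking hydrogen in place of chloro on an aromatic carbon of the aryl group gives a 2.5-fold lower number from compound 1 to compound 4 (0.41 log units; beyond the scatter) in this assay, the first step in this series that can be read. On this read-out a lower number means stronger inhibition of the cells, so a change of a single atom at this aryl group is enough to shift the result, and here the group with fewer chlorines gives the stronger effect. The exchange of 3,4,5-trimethoxyphenyl for 4-chlorophenyl cannot be read, as compound 3 has no number to compare, and nothing measured here explains the shift from chloro to hydrogen.

One step cannot say whether removing the remaining chlorine to leave a plain phenyl would lower the number further or raise it again. From the compounds shown here alone, it also remains open how other groups on this ring, such as a bromine, a nitrile, an amine or a carboxylic acid, would compare with the chlorine of compound 4.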